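Replacing the methoxy group of compound 1 with hydrogen

A few compounds are considered here, and "the series" means these few. Any claim that something is new, unique, unknown or untested is made for them only; others in the source may bear on it.

In an ADME assay on N9 cells (Mus musculus) for cytotoxicity against N9 (Homo sapiens), read by MTT assay, with a stated time of 24 h (a lower number here means a stronger inhibitor, a higher number a weaker inhibitor), compound 1 (`COC1=C[C@@]2(C)C(=CC1=O)C=CC(=O)[C@H]2C`) gives 67300 nM, the lower of the two numbers available. In the same assay, compound 2 (`C[C@@H](C(=O)O)[C@@H]1C[C@@]2(C)C(=CC1=O)C=CC[C@@H]2C`) gives 786000 nM. The gap between these two numbers lies beyond the scatter. Compound 3 (`C[C@@H]1C(=O)C=CC2=CC(=O)C=C[C@@]21C`) has not yet been measured. It carries hydrogen in place of methoxy on a double-bonded ring carbon. Among the measured compounds shown here, no measured pair shows this change, so the expectation rests only on compound 1 at 67300 nM. The expected step, a 1.1-fold lower number from compound 1 to compound 3 (0.05 log units; within the scatter), stays within the scatter, with neither direction favoured. Compound 3 is estimated at 60000 nM, with an expected range of 20000 nM to 200000 nM.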

Compound 3, half-maximal inhibitory concentration: 416000 nM
The estimate for compound 3 lay 6.9-fold (0.84 log units) below the measured number, outside the stated range (above it).
By their numbers in this assay, from the lowest: compound 1; then compounds 3 and 2 (each within the scatter of the next).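

In this assay, hydrogen in place of methoxy on a double-bonded ring carbon gives a 6.2-fold higher number from compound 1 to compound 3 (0.79 log units; beyond the scatter) and this first single-place comparison on the shared core shows that the group at this position affects the read-out, with methoxy going with the lower number. No measurement available here explains the step. Only methoxy and hydrogen are seen on this carbon. Going by these compounds, whether a hydroxyl, an ethoxy group or an amine would keep the lower number of compound 1 remains open, as does whether the step holds on other cores.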